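This account rests on a few compounds, and the source may have more. Where it says the series, first, only, none or still open, it means among the compounds named here.

Compound 3 `COc1ccc(CN(C(=O)CCCl)c2cc(OC)c(OC)c(OC)c2)cc1O` carries a 2-chloroethyl group on the carbonyl carbon of the shared core. Among the measured compounds shown here, in a functional assay on MGC-803 cells (Homo sapiens) for inhibition, read by MTT assay, with a stated time of 48 h (on this read-out higher numbers stand for weaker inhibition and lower numbers for stronger inhibition), compound 3 gives 140 nM, the highest of the three numbers known here. Compound 1 `CCC/C=C/C(=O)N(Cc1ccc(OC)c(O)c1)c1cc(OC)c(OC)c(OC)c1` gives 70 nM, and compound 2 `CCC(=O)N(Cc1ccc(OC)c(O)c1)c1cc(OC)c(OC)c(OC)c1` gives 50 nM. Only a 2.8-fold higher number from compound 2 to compound 3 (0.45 log units; beyond the scatter) reaches beyond the scatter; both a 2.0-fold higher number from compound 1 to compound 3 (0.30 log units; within the scatter) and a 1.4-fold lower number from compound 1 to compound 2 (0.15 log units; within the scatter) stay within it.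

Compound 4 `COc1ccc(CN(C(=O)C[Se]C#N)c2cc(OC)c(OC)c(OC)c2)cc1O` differs from compound 3 in one place: a group of 3 heavy atoms (1 carbon, 1 nitrogen, 1 selenium; no ring) in place of a group of 2 heavy atoms (1 carbon, 1 chlorine; no ring), on a saturated chain carbon bound to a carbonyl carbon. For the measured compounds named here, no measured pair makes this same exchange, so the closest guide is a 2.8-fold higher number from compound 2 to compound 3 (0.45 log units; beyond the scatter), which shows that a change on that saturated chain carbon can shift the number modestly, while the broader acyl variation seen in a 1.4-fold lower number from compound 1 to compound 2 (0.15 log units; within the scatter) stays within scatter. Going by the values given here, the incoming group has no precedent among the three compounds. Compound 4 is therefore expected to land near the others, with the step of a 1.6-fold lower number from compound 3 to compound 4 (0.19 log units; within the scatter) estimated to be small and uncertain in direction. Compound 4 is estimated in this assay at 90 nM, within a range from 35 nM to 250 nM.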

Compound 4, half-maximal inhibitory concentration: 270 nM
The estimate for compound 4 lay 3.0-fold (0.48 log units) below the measured number, and the stated range ends below it.
By their numbers in this assay, from the lowest: compounds 2, 1, 3 and 4 (each within the scatter of the next, the first and the last beyond it).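

On a saturated chain carbon bound to a carbonyl carbon, replacing chloromethyl with the selenium-bearing group gives a step that stays within the scatter in this assay (a 1.9-fold higher number from compound 3 to compound 4 (0.29 log units; within the scatter)), so this exchange alone does not separate compound 4 from compound 3. Among the compounds shown here, the same group does stand apart from the two other acyl groups (a 5.4-fold higher number from compound 2 to compound 4 (0.73 log units; beyond the scatter); a 3.9-fold higher number from compound 1 to compound 4 (0.59 log units; beyond the scatter)), and this is the first step from compound 1 to pass beyond the scatter, as earlier only the step from compound 2 had done (a 2.8-fold higher number from compound 2 to compound 3 (0.45 log units; beyond the scatter)). No measurement offered here accounts for this result.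

The compounds shown leave open whether a plain nitrile without selenium on that carbon would read like compound 4. They also leave open how an amine, a carboxylic acid or a longer chain there would read.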